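Chloro for fluoro at the edge of a cytotoxicity limit

This account rests on a few compounds, and the source may have more. Where it says the series, first, only, none or still open, it means among the compounds named here.

Values in a functional assay on HeLa cells (Homo sapiens) for cytotoxicity, with a stated time of 72 h; on this read-out higher numbers stand for weaker inhibition and lower numbers for stronger inhibition:
Compound 1, `Fc1ccc(-c2cn3nc(Cc4ccc(Cl)cc4)sc3n2)cc1`, gives > 250000 nM, which is a limit of the assay.
Compound 2, `Clc1ccc(Cc2nn3cc(-c4ccc(Cl)cc4Cl)nc3s2)cc1`, gives 109000 nM.
Compound 3, `Fc1ccc(-c2nc3sc(Cc4ccc(Cl)cc4)nn3c2Br)cc1`, gives > 250000 nM, which is a limit of the assay.

Compound 3 stands at the limit itself, so the assay gives no number for it, and it shares that position with compound 1, as noted in the limit of > 250000 nM in this assay, at which 2 of the 3 values shown sit. Going by the values given here, the only readable step among the three is an at least 2.2-fold lower number from compound 1 to compound 2 (0.36 log units; beyond the scatter), a change on the same six-membered carbon-only ring that is altered here. The step that the two limits leave unreadable from compound 1 to compound 3 adds nothing usable, because both ends sit at a limit.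

Compound 4, `Clc1ccc(Cc2nn3c(Br)c(-c4ccc(Cl)cc4)nc3s2)cc1`, differs from compound 3 by chloro in place of fluoro on an aromatic carbon. The step from compound 1 to compound 2 bears on it, since it also exchanges the 4-fluorophenyl for a chlorine-bearing ring, but that step put two chlorines in where compound 4 carries one, so its size is an upper guide rather than a match. A shift toward a lower number of modest size is therefore expected, with a real chance that the assay again reports only a limit.

Compound 4 is expected to give 180000 nM, within 70000 nM to 400000 nM. That estimate means a step of an at least 1.3-fold lower number from compound 3 to compound 4 (0.14 log units; that floor lies within the scatter), which is expected to be small.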

Compound 4, half-maximal inhibitory concentration: > 250000 nM
Compound 4 ended at the assay's limit; the forecaster's own chance of this, stated with the estimate: 55%; at least 1.3-fold (0.14 log units) between middle value and limit.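

In this assay compound 4 gives > 250000 nM, which is a limit of the assay and not a number. Compound 3 also stands at a limit, so no step between compound 3 and compound 4 can be read: the limit of > 250000 nM in this assay, at which 3 of the 4 values shown sit.

The compounds shown leave open whether 4-chlorophenyl in place of 4-fluorophenyl shifts the number in this assay at all.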